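Trading methoxy for fluoro on a benzyl group

A few compounds are considered here, and "the series" means these few. Any claim that something is new, unique, unknown or untested is made for them only; others in the source may bear on it.

Values from a functional assay on HT-29 cells (Homo sapiens) for inhibition, read by MTT assay, with a stated time of 48 h (a higher number here means a weaker inhibitor, a lower number a stronger inhibitor), follow.
Compound 1 `COc1ccc(-n2c(SCc3ccccc3)nnc2-c2cc(OC)c(OC)c(OC)c2)cc1` gives > 60000 nM as a limit
Compound 2 `COc1ccc(-n2c(SCc3ccc(C)cc3)nnc2-c2cc(OC)c(OC)c(OC)c2)cc1` gives > 60000 nM as a limit
Compound 3 `COc1ccc(CSc2nnc(-c3cc(OC)c(OC)c(OC)c3)n2-c2ccc(OC)cc2)cc1` gives > 60000 nM as a limit

On these data alone, compound 3 has no exact value, only a limit, so how strong an inhibitor it is remains unknown. The other two compounds offer no firmer reference, with the limit of > 60000 nM in this assay, at which 3 of the 3 values shown sit, and no exact value anywhere in the set.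

Compound 4 `COc1ccc(-n2c(SCc3ccc(F)cc3)nnc2-c2cc(OC)c(OC)c(OC)c2)cc1` differs from compound 3 in one place, with fluoro in place of methoxy on an aromatic carbon, turning 4-methoxybenzyl into 4-fluorobenzyl (fluoro in place of methoxy on an aromatic carbon).

Three measured changes touch that same place. They are a step that the two limits leave unreadable from compound 1 to compound 2 and a step that the two limits leave unreadable from compound 1 to compound 3 and also a step that the two limits leave unreadable from compound 2 to compound 3 and none has a size that can be read. They therefore give no direction for the new change, and no step beyond the usual scatter is expected in this assay on this evidence. The expected step is a number no higher from compound 3 to compound 4 (the limit leaves the size open) and this estimate rests on limits alone. For compound 4 the estimated value is 60000 nM with an expected range from 15000 nM to 120000 nM and a further limit is the likeliest report.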

Compound 4, half-maximal inhibitory concentration: 50700 nM
Beside the measured number, compound 4's estimate is 1.2-fold (0.07 log units) above it; measured number inside the range.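

In this assay, going by these compounds alone, compound 4 brings the first exact number to this set, so the place on the benzyl ring para to a large group can now be tied to a readable value rather than to a limit alone. Its steps are an at least 1.1-fold lower number from compound 3 to compound 4 (0.07 log units; that floor lies within the scatter), an at least 1.1-fold lower number from compound 2 to compound 4 (0.07 log units; that floor lies within the scatter) and an at least 1.1-fold lower number from compound 1 to compound 4 (0.07 log units; that floor lies within the scatter), so the change from methoxy to fluoro shows only a floor for the step, and this does not establish that the fluoro compound is the stronger inhibitor. The steps among compound 1, compound 2 and compound 3 still cannot be read, and the true size of each new step remains unknown, with the other compounds all resting on one limit: the limit of > 60000 nM in this assay, at which 3 of the 4 values shown sit.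

The compounds shown leave open whether a chloro or trifluoromethyl group, or an amine, at this same place would give a number clearly beyond the scatter from compound 4. They also leave open whether the fluoro group would give a similar reading if the methoxy groups on the rest of the shared core were changed.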